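Aryl ether variation in a prostacyclin synthase inhibitor series

The source may report more compounds than this note shows. Statements on the series, on what has been measured and on what is new or still open speak of the compounds shown alone.

Compound 1 `CSc1ccc(OC(C)(C)C2OCC(C/C=C\CCC(=O)O)C(c3cccnc3)O2)c([N+](=O)[O-])c1` gives 5000 nM in an assay for inhibition of prostacyclin synthase (Homo sapiens), using microsomes; a lower number here means a stronger inhibitor, a higher number a weaker inhibitor. Compound 2 `CC(C)(Oc1ccccc1O)C1OCC(C/C=C\CCC(=O)O)C(c2cccnc2)O1` returns only a limit in this assay, > 100000 nM. Going by the values given here, the single measured step, an at least 20-fold higher number from compound 1 to compound 2 (1.30 log units; beyond the scatter), rests on the limit of > 100000 nM in this assay, at which 1 of the 2 values shown sits, and so shows only a lower bound on the loss. Compound 3 `CC(C)(Oc1ccc(F)cc1[N+](=O)[O-])C1OCC(C/C=C\CCC(=O)O)C(c2cccnc2)O1` differs from compound 2 by 4-fluoro-2-nitrophenyl in place of 2-hydroxyphenyl on an oxygen on a saturated carbon. That step from compound 1 to compound 2 removed a nitro-substituted aryl ether and erased measurable activity; compound 3 reinstates a nitrophenyl ether and is therefore expected to recover, with a large fall in the number. Compound 3 is estimated at 8000 nM, range 2000 nM to 40000 nM, the expected step being an at least 12-fold lower number from compound 2 to compound 3 (1.09 log units; beyond the scatter).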

Compound 3, half-maximal inhibitory concentration: 9000 nM
The estimate for compound 3 lay 1.1-fold (0.05 log units) below the measured number, within the range that was stated.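

On the oxygen on a saturated carbon, 4-fluoro-2-nitrophenyl in place of 2-hydroxyphenyl gives an at least 11-fold lower number from compound 2 to compound 3 (1.04 log units; beyond the scatter), a lower bound only, set by the limit for compound 2: the limit of > 100000 nM in this assay, at which 1 of the 3 values shown sits. Fluoro in place of methylsulfanyl on an aromatic carbon gives a 1.8-fold higher number from compound 1 to compound 3 (0.26 log units; within the scatter), so measurable inhibition does not depend on methylsulfanyl in these two compounds.

The 2>3 exchange alters the nitro and fluoro groups together, so their separate shares remain unresolved. Also open, on these data alone, is what an amine or a nitrile would give in place of the nitro group.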